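Adding a Second Methoxy Group: Compound 3 to Compound 4

The compounds below may be only part of what the source reports. "The series", "measured", "known", "first", "only" and "open" are said of these compounds alone.

Of the compounds shown here, three built on a shared core have been tested in a functional assay on MDA-MB-231 cells (Homo sapiens) for inhibition, read by MTT assay, with a stated time of 72 h; a higher number here means a weaker inhibitor, a lower number a stronger inhibitor. Compound 1 `Cc1ccc2c(c1)/C(=c1/sc(=Cc3ccc(C=O)c(C=O)c3)c(=O)n1CCN(C)C)C(=O)N2` gives 8100 nM. Compound 2 `CN(C)CCn1c(=O)c(=Cc2ccc(F)c(F)c2)s/c1=C1\C(=O)Nc2cc(F)ccc21` gives 25000 nM in this assay . Compound 3 `COc1ccc(C=c2s/c(=C3\C(=O)Nc4cc(F)ccc43)n(CCN(C)C)c2=O)cc1` gives 2090 nM in this assay , the lowest of the three numbers, with compound 1 nearest to it and compound 2 furthest away. Within the data shown here, only one pair differs in a single place: a 12-fold lower number from compound 2 to compound 3 (1.08 log units; beyond the scatter).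

Compound 4 `COc1ccc(OC)c(C=c2s/c(=C3\C(=O)Nc4cc(F)ccc43)n(CCN(C)C)c2=O)c1` has not yet been measured. It differs from compound 3 in one place: 2,5-dimethoxyphenyl in place of 4-methoxyphenyl on a double-bonded chain carbon bound to an aromatic carbon. The step from compound 2 to compound 3 is the only one that touches this same ring, and it was large, but it exchanged two fluorine substituents for one methoxy group. Among the measured compounds shown here, no measured step shows what happens when a methoxy-bearing ring gains a second methoxy group. With no direct guide, a change of no clear direction is expected, most likely within the scatter, and the step is estimated as a 1.2-fold higher number from compound 3 to compound 4 (0.08 log units; within the scatter). In this assay compound 4 is therefore expected at about 2500 nM, within a range from 800 nM to 8000 nM.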

Compound 4, half-maximal inhibitory concentration: 14500 nM
The estimate for compound 4 lay 5.8-fold (0.76 log units) below the measured number; measured number outside the range, above it.
By their numbers in this assay, from the lowest: compound 3; then compounds 1, 4 and 2 (each within the scatter of the next, the first and the last beyond it).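

The ring on this double-bonded chain carbon does not simply tolerate an extra methoxy group: in this assay, exchanging 4-methoxyphenyl for 2,5-dimethoxyphenyl gives a 6.9-fold higher number from compound 3 to compound 4 (0.84 log units; beyond the scatter), so more methoxy groups did not bring a stronger inhibitor here. A methoxy group on this ring is also not enough on its own to separate a compound from the difluoro analogue: the 2,5-dimethoxyphenyl and 3,4-difluorophenyl compounds sit level, with a 1.7-fold lower number from compound 2 to compound 4 (0.24 log units; within the scatter), whereas only the 4-methoxyphenyl ring stood apart, with a 12-fold lower number from compound 2 to compound 3 (1.08 log units; beyond the scatter). No measurement available here explains why the two methoxy-bearing rings behave so differently.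

The number of methoxy groups and their placing remain tangled: 4-methoxyphenyl and 2,5-dimethoxyphenyl differ in both, so this single step cannot say which of the two matters. On these data alone, it also remains open how this position would respond to a ring carrying a hydroxyl group or an amine in place of methoxy, or to a longer ether chain such as ethoxy.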